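The source may report more compounds than this note shows. Statements on the series, on what has been measured and on what is new or still open speak of the compounds shown alone.

For the measured compounds named here, in a functional assay on HCT-116 cells (Homo sapiens) for antiproliferative activity, read by MTT assay, with a stated time of 48 h (on this read-out higher numbers stand for weaker inhibition and lower numbers for stronger inhibition), compound 1 `COc1ccc(CN(C(=O)CSc2nc3ccccc3s2)c2cc(OC)c(OC)c(OC)c2)cc1O` gives 182 nM, the lowest number of the three measured so far and thus the strongest inhibition. Compound 2 `COc1cc(N(Cc2ccccc2)C(=O)CSc2nc3ccccc3s2)cc(OC)c1OC` gives 54500 nM, and compound 3 `COc1ccc(CN(C(=O)CSc2nc3c(C)cccc3s2)c2cc(OC)c(OC)c(OC)c2)cc1O` gives 852 nM. Compound 4 `COc1ccc(CN(C(=O)CSc2nc3ccccc3s2)c2cc(OC)c(OC)c(OC)c2)cc1Br` differs from compound 1 at one place: bromo in place of hydroxy on an aromatic carbon. Going by the values given here, two measured steps bear on this. Losing the whole 3-hydroxy-4-methoxyphenyl group to phenyl gave the large 300-fold higher number from compound 1 to compound 2 (2.48 log units; beyond the scatter), while adding a methyl gave the modest 4.7-fold higher number from compound 1 to compound 3 (0.67 log units; beyond the scatter). Compound 4 keeps the methoxy group, so a rise nearer the modest step is expected in this assay. The estimated change is a 4.9-fold higher number from compound 1 to compound 4 (0.69 log units; beyond the scatter). For compound 4, the expected value is 900 nM, with an estimated range of 250 nM to 6000 nM.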

Compound 4, half-maximal inhibitory concentration: 4550 nM
Estimate against measurement, compound 4: 5.1-fold (0.70 log units) below; the measured number falls inside the stated range.
By their numbers in this assay, from the lowest: compound 1; then compound 3; then compound 4; then compound 2.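

Swapping only the hydroxy for bromo, with the methoxy group kept, costs much of the inhibition in this assay, giving a 25-fold higher number from compound 1 to compound 4 (1.40 log units; beyond the scatter). Yet the 3-bromo-4-methoxyphenyl group still far outperforms plain phenyl, with a 12-fold lower number from compound 2 to compound 4 (1.08 log units; beyond the scatter), so the hydroxy accounts for only part of what separates the 3-hydroxy-4-methoxyphenyl group from phenyl. No measurement here explains the size of either step. From the compounds shown here alone, it remains open whether an amino group or a fluoro at this place would stay closer to compound 1, and what the methoxy group achieves with only hydrogen there.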